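A Small Swap on the Amide Nitrogen

The source may report more compounds than this note shows. Statements on the series, on what has been measured and on what is new or still open speak of the compounds shown alone.

In a functional assay on A549 cells (Homo sapiens) for inhibition, read by MTT assay, with a stated time of 72 h (a higher number here means a weaker inhibitor, a lower number a stronger inhibitor), compound 1 (`Cc1ccc(NC(=O)C2CCN(C/C=C/c3ccccc3)CC2)cc1`) gives 29600 nM. Compound 2 (`CCc1ccc(NC(=O)C2CCN(C/C=C/c3ccccc3)CC2)cc1`) gives 19600 nM and compound 3 (`O=C(Nc1cccc(C(F)(F)F)c1)C1CCN(C/C=C/c2ccccc2)CC1`) gives 15600 nM, which leaves compound 1 within the scatter of both. Compound 4 (`O=C(Nc1cccc(F)c1)C1CCN(C/C=C/c2ccccc2)CC1`) is compound 1 with one group exchanged: 3-fluorophenyl in place of 4-methylphenyl on an amide-type nitrogen. Its 3-fluorophenyl takes the place of 4-methylphenyl on an amide-type nitrogen. Going by the values given here, the one measured step that bears on this, a 1.5-fold lower number from compound 1 to compound 2 (0.18 log units; within the scatter), also alters that aromatic group and stays small. Compound 3, at 15600 nM, likewise stays close to compound 1. No change beyond the scatter is therefore expected. The estimated step is a 1.6-fold lower number from compound 1 to compound 4 (0.22 log units; within the scatter). For compound 4 the expected value is 18000 nM, with an estimated range of 9000 nM to 36000 nM.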

Compound 4, half-maximal inhibitory concentration: 43300 nM
For compound 4 the middle estimate is 2.4-fold (0.38 log units) below the measured one; measured number above the stated range.
By their numbers in this assay, from the lowest: compounds 3, 2, 1 and 4 (each within the scatter of the next, the first and the last beyond it).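

The 3-fluorophenyl swap leaves compound 4 level with compound 1, at a 1.5-fold higher number from compound 1 to compound 4 (0.17 log units; within the scatter). Even so, the aromatic group on the amide-type nitrogen can separate these compounds modestly, since fluoro in place of trifluoromethyl gives a 2.8-fold higher number from compound 3 to compound 4 (0.44 log units; beyond the scatter) and 3-fluorophenyl in place of 4-ethylphenyl gives a 2.2-fold higher number from compound 2 to compound 4 (0.34 log units; beyond the scatter). No measurement is available that accounts for these gaps. As far as these compounds go, it remains open whether a larger change on this aromatic group, such as an amine or a carboxylic acid, would produce a larger step. A methoxy group is equally untested among the compounds shown.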